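A few compounds are considered here, and "the series" means these few. Any claim that something is new, unique, unknown or untested is made for them only; others in the source may bear on it.

Compound 1, `Cc1ccc(Cn2cc(COc3ccc4c(=O)ccoc4c3)nn2)cc1`: 50700 nM
Compound 2, `N#Cc1ccc(Cn2cc(COc3ccc4c(=O)ccoc4c3)nn2)cc1`: > 100000 nM
Compound 3, `O=c1ccoc2cc(OCc3cn(Cc4ccccc4Br)nn3)ccc12`: > 100000 nM

Of the compounds shown here, three built on the same core have been tested in a functional assay on A549 cells (Homo sapiens) for cytotoxicity, read by MTT assay, with a stated time of 48 h; a lower number here means a stronger inhibitor, a higher number a weaker inhibitor. Compound 1 gives 50700 nM. For compound 2 the assay reports only a limit, > 100000 nM, not a number. For compound 3 the assay likewise reports only a limit, > 100000 nM. Compound 3 thus stands at the limit of > 100000 nM in this assay, at which 2 of the 3 values shown sit, the weak end of what this assay can read.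

Compound 4, `O=c1ccoc2cc(OCc3cn(Cc4cccc(Br)c4)nn3)ccc12`, differs from compound 3 in one place: 3-bromophenyl in place of 2-bromophenyl on a saturated chain carbon bound to an aromatic nitrogen. For the measured compounds named here, two measured steps touch the same benzyl group and so bear on this change. The first is an at least 1.9-fold higher number from compound 1 to compound 3 (0.29 log units; that floor lies within the scatter). The second is a step that the two limits leave unreadable from compound 2 to compound 3. Neither gives a readable size, and the shift of bromine from one ring position to another is smaller than either of those changes. The expectation for compound 4 is therefore a step of a number no higher from compound 3 to compound 4 (the limit leaves the size open), meaning no change beyond the scatter from compound 3. Compound 4 is estimated at 100000 nM, with a range from 30000 nM to 300000 nM, and a number rather than a limit is itself uncertain.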

Compound 4, half-maximal inhibitory concentration: > 100000 nM
Compound 4 gave a limit, no number; the forecaster's own chance of this, stated with the estimate: 65%; the middle value sits exactly at the limit.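

With the bromine on a 3-bromophenyl rather than a 2-bromophenyl group, the compound still returns no number in this assay, so these two bromine placements cannot be told apart in this assay: the limit of > 100000 nM in this assay, at which 3 of the 4 values shown sit. The steps to compound 4 from compound 2 and from compound 3 cannot be read, as both ends of each are limits. For the compounds shown here, the one readable step is an at least 1.9-fold higher number from compound 1 to compound 4 (0.29 log units; that floor lies within the scatter), so even the comparison with the 4-methylphenyl group does not establish a change beyond the scatter.

On these data alone, how far compounds 2, 3 and 4 lie past the limit, and whether they differ from one another at all, stays open. Also open, as far as these compounds go, is whether an amine or a carboxylic acid on the phenyl ring would give a number lower than that of compound 1, 50700 nM.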